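Amine swap on the side chain: dimethylamino to pyrrolidin-1-yl

A few compounds are considered here, and "the series" means these few. Any claim that something is new, unique, unknown or untested is made for them only; others in the source may bear on it.

Measured so far:
Compound 1 `O=C(CCN1CCCCC1)c1cc2ccc(O)cc2oc1=O` gives > 200000 nM in an assay on cells for inhibition of Amine oxidase [flavin-containing] A (Homo sapiens), read by fluorescence, spectrophotometry and Amplex Red, with stated times of 60 min and 30 min; a lower number here means a stronger inhibitor, a higher number a weaker inhibitor; this is a limit of the assay, not a number.
Compound 2 `CN(C)CCC(=O)c1cc2cc(Br)c(O)c(Br)c2oc1=O` gives > 200000 nM in this assay; again only a limit, not a number.

Within the data shown here, compound 2 therefore stands at the limit and nowhere else; both values shown so far sit at the limit of > 200000 nM in this assay, at which 2 of the 2 values shown sit, so no ranking within the pair is possible. Compound 3 `O=C(CCN1CCCC1)c1cc2cc(Br)c(O)c(Br)c2oc1=O` carries pyrrolidin-1-yl in place of dimethylamino on a saturated chain carbon, two bonds along the chain from a carbonyl carbon. Among the measured compounds shown here, no step between measured compounds exists here, and the shared core of compound 2 and compound 3 has yet to give any number, so the data offer no direction for this change. In this assay the step that the limit leaves unreadable from compound 2 to compound 3 is expected to be none beyond the scatter. Compound 3 is accordingly estimated at 300000 nM, with a range from 100000 nM to 1000000 nM, and most probably reported again only as a limit.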

Compound 3, half-maximal inhibitory concentration: 155000 nM
The estimate for compound 3 lay 1.9-fold (0.29 log units) above the measured number; measured number inside the range.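

In this assay, among these compounds, compound 3 gives 155000 nM, the only value shown that is not a limit, so the shared core with pyrrolidin-1-yl on the chain does give a number. Compound 2 gives > 200000 nM, which is a limit of the assay and not a number. Pyrrolidin-1-yl in place of dimethylamino therefore reads only as an at least 1.2-fold lower number from compound 2 to compound 3 (0.11 log units; that floor lies within the scatter), and the true size of the change stays unknown because one end of the step is a limit: the limit of > 200000 nM in this assay, at which 2 of the 3 values shown sit.

On these data alone, whether this change goes beyond the scatter remains open, since only a floor is available. Also open, as far as these compounds go, is how another amine such as morpholin-4-yl, or a longer chain carrying the pyrrolidin-1-yl, would read at this place on the same core.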